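The source may hold more compounds than are shown below. What is called first, only, known or untested is meant among the compounds shown, and "the series" means these compounds.

Compound 1 `O=C(Nc1ccc(F)c(-c2nc3ccccc3s2)c1)c1cc([N+](=O)[O-])ccc1Cl` and compound 2 `O=C(Nc1cccc(-c2nc3ccccc3s2)c1)c1cc([N+](=O)[O-])ccc1Cl` rest on the same core and differ in one place, described as fluoro in place of hydrogen on an aromatic carbon. In an ADME assay on Raji cells (Homo sapiens) for cytotoxicity, with a stated time of 72 h (on this read-out lower numbers stand for an effect already at smaller amounts and higher numbers for an effect only at larger amounts of compound), compound 1 gives only a limit, > 25000 nM. In this assay compound 2 likewise gives only a limit, > 27000 nM. The step that the two limits leave unreadable from compound 2 to compound 1 therefore cannot be read because the limit of > 25000 nM in this assay, at which 1 of the 3 values shown sits, and the limit of > 27000 nM in this assay, at which 1 of the 3 values shown sits, offer no number to compare.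

Compound 3 `O=C(Nc1nc(-c2cccc(F)c2)cs1)c1cc([N+](=O)[O-])ccc1Cl` sits on a different core; the difference between the two cores is not broken down here. In this assay, within the data shown here, compound 3 gives 11000 nM, the only plain number among the three measured compounds.

Compound 4 `O=C(Nc1nc(-c2ccc(F)c(F)c2)cs1)c1cc([N+](=O)[O-])ccc1Cl` has not yet been measured. It differs from compound 3 by fluoro in place of hydrogen on an aromatic carbon. This is the same kind of change as that from compound 2 to compound 1, though not the same: in compound 4 the entering fluoro sits ortho to a fluoro group, whereas in compound 1 it sits ortho to a 1,3-benzothiazol-2-yl group. The measured pair yields no readable size for this change, so the expectation for compound 4 rests mainly on compound 3 and its value 11000 nM. A small step is expected, a 1.1-fold higher number from compound 3 to compound 4 (0.04 log units; within the scatter), since one added fluoro is a slight change to the molecule. Compound 4 is accordingly estimated at 12000 nM, expected to fall between 5000 nM and 30000 nM.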

Compound 4, half-maximal effective concentration: 13000 nM
Estimate against measurement, compound 4: 1.1-fold (0.03 log units) below, and the stated range covers the measured number.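

In this assay, fluoro in place of hydrogen on the core of compound 3, which turns 3-fluorophenyl into 3,4-difluorophenyl, gives a 1.2-fold higher number from compound 3 to compound 4 (0.07 log units; within the scatter), so on this core the change shows no effect beyond the usual scatter. On the other core, compound 1 gives only a limit and no number: the limit of > 25000 nM in this assay, at which 1 of the 4 values shown sits. Among these compounds, compound 2 also gives only a limit, so the step between these two cannot be read, and the single readable pair does not show whether the change carries over from one core to the other, in size or in direction: the limit of > 27000 nM in this assay, at which 1 of the 4 values shown sits.

The compounds shown leave open how the number in this assay responds when a group other than fluoro enters on the phenyl ring, such as a chloro, a methoxy, an amine or a carboxylic acid. They also leave open what happens when the nitro group, which all of them carry, gives way to an amine or a nitrile, or when a longer chain stands in the place of the amide link.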